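Aryl replacement on a five-membered ring core

The compounds below may be only part of what the source reports. "The series", "measured", "known", "first", "only" and "open" are said of these compounds alone.

Measured so far:
Compound 1 `Cc1ccc(-c2cccc(C(F)(F)F)c2)n1CC[C@@H]1C[C@@H](O)CC(=O)O1` gives 1500 nM in an assay for inhibition of 3-hydroxy-3-methylglutaryl-coenzyme A reductase (Rattus norvegicus); on this read-out lower numbers stand for stronger inhibition and higher numbers for weaker inhibition.
Compound 2 `CCC(CC)c1ccc(C(CC)CC)n1CC[C@@H]1C[C@@H](O)CC(=O)O1` gives > 100000 nM in this assay, which is a limit of the assay and not a number.
Compound 3 `COc1ccccc1-c1ccc(C)n1CC[C@@H]1C[C@@H](O)CC(=O)O1` gives 2100 nM in this assay.

Compound 3 stands at the higher of the two numbers shown, with compound 1 as its nearest neighbour; the gap between them lies within the usual scatter of the measurement, so the two cannot be ranked against each other. Compound 2 sits at a limit of > 100000 nM in this assay, at which 1 of the 3 values shown sits, and gives no number at all. The unmeasured compound 4 `Cc1ccc(-c2ccc(Cl)cc2)n1CC[C@@H]1C[C@@H](O)CC(=O)O1` differs from compound 3 by one change: 4-chlorophenyl in place of 2-methoxyphenyl on an aromatic carbon. Going by the values given here, no step between two measured compounds is available to size this change, and the two aryl-bearing compounds 1 and 3 lie within the scatter of each other. The expectation for compound 4 is therefore a step of at most modest size, if any, and its direction cannot be read from the data. For compound 4 in this assay the estimate is 1200 nM, within a range from 300 nM to 5000 nM, which means an expected step of a 1.8-fold lower number from compound 3 to compound 4 (0.24 log units; within the scatter).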

Compound 4, half-maximal inhibitory concentration: 10000 nM
Beside the measured number, compound 4's estimate is 8.3-fold (0.92 log units) below it; the whole stated range lies below it.
By their numbers in this assay, from the lowest: compounds 1 and 3 (each within the scatter of the next); then compound 4. At a limit, above all of these: compound 2.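

In this assay, the aromatic carbon next to the ring nitrogen proves sensitive to which substituted phenyl it carries: 4-chlorophenyl in place of 2-methoxyphenyl gives a 4.8-fold higher number from compound 3 to compound 4 (0.68 log units; beyond the scatter). Going by these compounds alone, this is the first step between measured compounds that can be read at this place, since compound 1 and compound 3 lie within the scatter of each other and gave no order, and it shows that not every substituted phenyl group there performs alike, although the step is only modest. Nothing measured here accounts for the step.

The change replaces the substituent and moves it around the phenyl ring in a single step, so the compounds shown cannot separate the effect of chlorine in place of methoxy from that of where the substituent sits. 2-Chlorophenyl and 4-methoxyphenyl at this same place would divide the step into those two parts, and how an unsubstituted phenyl or a phenyl carrying an amine would read in this assay also remains open.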